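Thiourea and urea pairs: chloro to fluoro swap

The compounds below may be only part of what the source reports. "The series", "measured", "known", "first", "only" and "open" are said of these compounds alone.

Measured so far:
compound 1, `CNC(=O)c1ccc(Sc2cccc(NC(=S)Nc3ccc(Cl)c(C(F)(F)F)c3)c2)nc1`, 5180 nM in a functional assay on HCT-116 cells (Homo sapiens) for cytotoxicity, read by MTT assay, with a stated time of 48 h; on this read-out higher numbers stand for weaker inhibition and lower numbers for stronger inhibition
compound 2, `CNC(=O)c1ccc(Sc2cccc(NC(=S)Nc3ccc(F)c(C(F)(F)F)c3)c2)nc1`, 18200 nM in this assay
compound 3, `CNC(=O)c1ccc(Sc2ccc(NC(=O)Nc3ccc(Cl)c(C(F)(F)F)c3)cc2)nc1`, 5290 nM in this assay

Compound 1 and compound 2 share one core; compound 3 and compound 4 share another. How the two cores differ is not broken down here. Within the first pair, compound 2 carries fluoro in place of chloro on an aromatic carbon relative to compound 1, and this gave a 3.5-fold higher number from compound 1 to compound 2 (0.55 log units; beyond the scatter) in this assay.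

Compound 4, `CNC(=O)c1ccc(Sc2ccc(NC(=O)Nc3ccc(F)c(C(F)(F)F)c3)cc2)nc1`, has not yet been measured. Among the measured compounds shown here, it carries fluoro in place of chloro on an aromatic carbon relative to compound 3, the same change as the one between compound 1 and compound 2, made on the second core. Compound 3 gives 5290 nM in this assay, and its value and that of compound 1 lie within the scatter of each other, so the two cores start from much the same point.

For the measured compounds named here, only one example of this change is measured, so the expectation rests on a single step. With that caveat, compound 4 is expected to show a 3.0-fold higher number from compound 3 to compound 4 (0.48 log units; beyond the scatter) in this assay, a step of about the size seen from compound 1 to compound 2, because that step was a 3.5-fold higher number from compound 1 to compound 2 (0.55 log units; beyond the scatter) and the two cores stand at similar values before the change. On this basis compound 4 is estimated at 16000 nM in this assay, with a likely range from 7000 nM to 40000 nM.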

Compound 4, half-maximal inhibitory concentration: 5800 nM
Beside the measured number, compound 4's estimate is 2.8-fold (0.44 log units) above it; measured number below the stated range.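

In this assay, fluoro in place of chloro on an aromatic carbon now gives a 1.1-fold higher number from compound 3 to compound 4 (0.04 log units; within the scatter), so on this core the swap produces no readable step. The change does not carry over in size from one core to the other: the same change on two cores in this assay, a 3.5-fold higher number (0.55 log units; beyond the scatter) from compound 1 to compound 2 and a 1.1-fold higher number (0.04 log units; within the scatter) from compound 3 to compound 4, 3.2-fold (0.51 log units) apart, beyond the scatter of two such steps. Among the compounds shown here, this shows that the weaker result on the core of compound 1 cannot be taken as a general penalty for fluoro, but with only one pair on each core it does not show which of the differences between the two cores separates the steps, or how either step would read on a third core.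

All four compounds shown keep the trifluoromethyl group and carry only chloro or fluoro on that aromatic carbon, so it remains open how the two cores would respond to bromo, methoxy or an amine at that place. Also open, going by these compounds, is whether the same split between the cores would hold with a carboxylic acid or a longer chain in place of the methyl amide, and whether it would appear in any read-out other than this one.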